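Swapping the amide aryl group for a dimethylphenyl

The source may hold more compounds than are shown below. What is called first, only, known or untested is meant among the compounds shown, and "the series" means these compounds.

In a functional assay on HCC1937 cells (Homo sapiens) for antiproliferative activity, read by CCK-8 assay, with a stated time of 72 h (on this read-out lower numbers stand for stronger inhibition and higher numbers for weaker inhibition), compound 2 `COc1ccc(C(=O)Nc2cccc(-c3oc4cc(-c5ccc(F)cc5)ccc4c(=O)c3O)c2)c(F)c1` gives 24500 nM. Going by the values given here, the only other measured compound, compound 1 `COc1cccc(C(=O)Nc2cccc(-c3oc4cc(-c5ccc(F)cc5)ccc4c(=O)c3O)c2)c1`, gives 18900 nM, and the step of a 1.3-fold higher number from compound 1 to compound 2 (0.11 log units; within the scatter) stays within the scatter, so the two cannot be told apart. Compound 3 `Cc1cc(C)cc(C(=O)Nc2cccc(-c3oc4cc(-c5ccc(F)cc5)ccc4c(=O)c3O)c2)c1` carries the change (3,5-dimethylphenyl in place of 2-fluoro-4-methoxyphenyl on a carbonyl carbon). Among the compounds with values here, only that one earlier step bears on it: an exchange of the aryl group on the same carbonyl carbon left the read-out essentially unchanged, so the step of a 1.1-fold lower number from compound 2 to compound 3 (0.05 log units; within the scatter) is expected to stay within the scatter as well. Compound 3 is therefore estimated at 22000 nM, within a range from 8000 nM to 60000 nM.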

Compound 3, half-maximal inhibitory concentration: 4860 nM
The estimate for compound 3 lay 4.5-fold (0.66 log units) above the measured number; the measured number lies below the stated range.
By their numbers in this assay, from the lowest: compound 3; then compounds 1 and 2 (each within the scatter of the next).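

In this assay this position turns out not to be indifferent to the aryl group on the carbonyl carbon. The 3,5-dimethylphenyl group gives a 5.0-fold lower number from compound 2 to compound 3 (0.70 log units; beyond the scatter) and also a 3.9-fold lower number from compound 1 to compound 3 (0.59 log units; beyond the scatter) while the rest of the molecule stays the same. Going by these compounds alone, compound 1 and compound 2 could not be told apart, so this is the first change at this position that clearly moves the number.

On these data alone, it remains open whether both methyl groups are needed, and whether an amine or a carboxylic acid on this ring would keep the lower number. Nothing available explains why the 3,5-dimethylphenyl group behaves differently.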